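The compounds below may be only part of what the source reports. "The series", "measured", "known", "first", "only" and "open" are said of these compounds alone.

For the measured compounds named here, in a functional assay on PC-3 cells (Homo sapiens) for cytotoxicity, read by WST assay, with a stated time of 24 h (on this read-out lower numbers stand for stronger inhibition and higher numbers for weaker inhibition), compound 1 `COc1ccc2[nH]cc(/C=C(\C#N)C(=O)c3c[nH]c4ccccc34)c2c1` gives 33200 nM, the only exact number among the three compounds measured so far. Compound 2 `COc1ccc2[nH]cc(/C=C(\C#N)C(=O)c3c[nH]c4ccc(OC)cc34)c2c1` reaches only a limit of the assay, > 50000 nM. Compound 3 `N#C/C(=C\c1c[nH]c2ccccc12)C(=O)c1c[nH]c2ccccc12` also reaches only a limit, > 50000 nM.

The untested compound 4 `COc1ccc2c(C(=O)/C(C#N)=C/c3c[nH]c4ccc(OC)cc34)c[nH]c2c1` keeps the core of compound 1 and changes it in one place, (methoxy in place of hydrogen on an aromatic carbon). This is methoxy in place of hydrogen on an aromatic carbon, meta to a fused ring and para to a fused ring.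

Going by the values given here, two measured steps bear on this change. Compound 2 carries the same kind of change on a different carbon, which gave an at least 1.5-fold higher number from compound 1 to compound 2 (0.17 log units; that floor lies within the scatter). Compound 3 instead has hydrogen in place of methoxy on an aromatic carbon, which gave an at least 1.5-fold higher number from compound 1 to compound 3 (0.17 log units; that floor lies within the scatter). Because of the limit of > 50000 nM in this assay, at which 2 of the 3 values shown sit, each step is known only as a floor, and neither floor goes beyond the scatter.

Adding and removing methoxy both led to a limit, so these steps give only a weak lean towards a higher number. A small move in that direction is expected, probably not beyond the scatter, and compound 4 may also reach the limit. The estimated step is a 1.3-fold higher number from compound 1 to compound 4 (0.10 log units; within the scatter). For compound 4 the expected value is 42000 nM, within an estimated range from 18000 nM to 90000 nM.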

Compound 4, half-maximal inhibitory concentration: 31100 nM
Beside the measured number, compound 4's estimate is 1.4-fold (0.13 log units) above it; the range from low to high includes it.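

In this assay, this step can be read as a real number rather than a floor: a 1.1-fold lower number from compound 1 to compound 4 (0.03 log units; within the scatter). Methoxy on this carbon, meta to a fused ring and para to a fused ring, therefore keeps compound 4 within the usual scatter of compound 1, and compound 4 stays inside the measurable range instead of reaching the limit of the assay. The earlier steps to compound 2 and compound 3 could not show this, because each is known only as a floor: the limit of > 50000 nM in this assay, at which 2 of the 4 values shown sit.

Going by these compounds, it remains open whether any group on this carbon can move the number beyond the scatter, as an amine, a carboxylic acid or a longer chain such as ethoxy might behave quite differently from methoxy. On these data alone, it also remains open how far compound 2 and compound 3 really lie from compound 1, as their values are limits and not numbers.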